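Swapping the pyridyl arm for a fluorophenyl on the shared core

The source may hold more compounds than are shown below. What is called first, only, known or untested is meant among the compounds shown, and "the series" means these compounds.

Of the compounds shown here, three sharing one core have been measured in a functional assay on HepG2 cells (Homo sapiens) for antiproliferative activity, read by MTT assay; on this read-out lower numbers stand for stronger inhibition and higher numbers for weaker inhibition. Compound 1 `COc1ccc(/C=C2/SC(N3CCC[C@H]3C(=O)Nc3ccc4ncnc(Nc5cccc(Cl)c5)c4c3)=NC2=O)cc1` gives 19000 nM, compound 2 `Cc1cccc(/C=C2/SC(N3CCC[C@H]3C(=O)Nc3ccc4ncnc(Nc5cccc(Cl)c5)c4c3)=NC2=O)n1` gives 4500 nM, and compound 3 `O=C1N=C(N2CCC[C@H]2C(=O)Nc2ccc3ncnc(Nc4cccc(Cl)c4)c3c2)S/C1=C/c1ccccc1[N+](=O)[O-]` gives 32500 nM. Compound 2 stands lowest of the three, with a 4.2-fold lower number from compound 1 to compound 2 (0.63 log units; beyond the scatter) and a 7.2-fold higher number from compound 2 to compound 3 (0.86 log units; beyond the scatter) both beyond the scatter. Compound 4 `O=C1N=C(N2CCC[C@H]2C(=O)Nc2ccc3ncnc(Nc4cccc(Cl)c4)c3c2)S/C1=C/c1ccccc1F` is not yet measured; it differs from compound 2 by 2-fluorophenyl in place of 6-methylpyridin-2-yl on a double-bonded chain carbon bound to a double-bonded ring carbon. Both earlier exchanges of the group on that chain carbon for a phenyl ring gave weaker inhibition relative to compound 2, so a higher number is expected for compound 4 as well, although smaller than the nitrophenyl step. The estimate for compound 4 is 15000 nM, within 6000 nM to 40000 nM, which means an expected 3.3-fold higher number from compound 2 to compound 4 (0.52 log units; beyond the scatter).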

Compound 4, half-maximal inhibitory concentration: 18200 nM
The estimate for compound 4 lay 1.2-fold (0.08 log units) below the measured number, within the range that was stated.
By their numbers in this assay, from the lowest: compound 2; then compounds 4, 1 and 3 (each within the scatter of the next).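

In this assay the exchange gives a 4.0-fold higher number from compound 2 to compound 4 (0.61 log units; beyond the scatter) and so shows that a carbon-only ring carrying fluorine also falls short of the 6-methylpyridin-2-yl group on this chain carbon. The two other aromatic rings do not separate from the 2-fluorophenyl, with a 1.8-fold lower number from compound 3 to compound 4 (0.25 log units; within the scatter) and a 1.0-fold lower number from compound 1 to compound 4 (0.02 log units; within the scatter) both printed within the scatter, so compound 2 alone stands apart among the four. Nothing at hand explains that gap.

The compounds shown leave open whether the ring nitrogen or the methyl of compound 2 carries the difference, and how an unsubstituted pyridin-2-yl or a phenyl ring bearing an amine would read on this chain carbon.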